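The compounds below may be only part of what the source reports. "The series", "measured", "known", "first", "only" and "open" are said of these compounds alone.

Three stereoisomers of one hydroxylated piperidine carboxylic acid have been tested in an assay on isolated protein for inhibition of cytosolic endo-beta-N-acetylglucosaminidase (Homo sapiens), tested at 1000 uM; on this read-out higher numbers stand for more inhibition at the one concentration tested (going by the name of the read-out) and lower numbers for less inhibition. Compound 1 `O=C(O)[C@H]1NC[C@H](O)[C@H](O)[C@@H]1O` gives 26%, and its mirror image compound 2 `O=C(O)[C@@H]1NC[C@@H](O)[C@@H](O)[C@H]1O` gives 26%, so there is no change at the digits printed from compound 1 to compound 2 (within the scatter). Compound 3 `O=C(O)[C@@H]1NC[C@@H](O)[C@@H](O)[C@@H]1O` gives 2.1%, the lowest of the three numbers. Compound 4 `O=C(O)[C@@H]1NC[C@H](O)[C@@H](O)[C@@H]1O` differs from compound 3 only in this way: the two compounds have the same atoms and bonds and differ only in configuration as drawn: 1 of 4 stereo elements differ; a stereocentre at a saturated ring carbon is drawn R in compound 3 and S in compound 4. The step that bears on it is a number 23.9 percentage points lower from compound 2 to compound 3 (beyond the scatter), a single inverted stereocentre, though at a different ring carbon. A single inversion can thus move this read-out by a modest amount in either direction. Compound 4 is therefore expected to show a number 9.9 percentage points higher from compound 3 to compound 4 (within the scatter), landing at an estimated 12% with a range from 0% to 30%.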

Compound 4, a percentage reported as inhibition, at one concentration (the size of the read-out at that concentration, not a potency): 5.4%
The estimate for compound 4 lay 6.6 percentage points above the measured number; the measured number falls inside the stated range.
By their numbers in this assay, from the lowest: compounds 3 and 4 (each within the scatter of the next); then compounds 1 and 2 (each within the scatter of the next).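

In this assay, inverting this one stereocentre gives a number 3.3 percentage points higher from compound 3 to compound 4 (within the scatter), whereas the single inversion at another ring carbon gave a number 23.9 percentage points lower from compound 2 to compound 3 (beyond the scatter). Among these compounds, then, a single inversion does not always shift the read-out, and which ring carbon is inverted makes a difference. The further steps, a number 20.6 percentage points lower from compound 2 to compound 4 (beyond the scatter) and a number 20.6 percentage points lower from compound 1 to compound 4 (beyond the scatter), keep compound 4 clearly apart from the mirror-image pair.

Every compound shown carries the carboxylic acid, so what an amide in its place would do stays open. Readings at a single concentration also leave the potency of all four compounds unknown.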